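This account rests on a few compounds, and the source may have more. Where it says the series, first, only, none or still open, it means among the compounds named here.

Compound 1 `COc1cc(-c2cc(/C=C/C(=O)c3ccc(N)cc3)[nH]n2)cc(OC)c1OC` gives, as a limit of the assay, > 100000 nM.
Compound 2 `COc1cc(-c2cc(/C=C/C(=O)c3ccc(Cl)c(Cl)c3)[nH]n2)cc(OC)c1OC` gives, as a limit of the assay, > 100000 nM.
Compound 3 `COc1ccc(-c2cc(/C=C/C(=O)c3ccc(N)cc3)[nH]n2)cc1OC` gives, as a limit of the assay, > 100000 nM.

All three compounds share the same core and were tested in a functional assay on PC-3 cells (Homo sapiens) for inhibition, read by sulforhodamine B assay, with a stated time of 48 h; a higher number here means that more compound is tolerated, a lower number that less compound is tolerated. None of them yields a number. Compound 2 stands only at a limit in this assay; its reading is one of the three that sit at the same limit, (the limit of > 100000 nM in this assay, at which 3 of the 3 values shown sit). Two measured steps lead away from compound 1: a step that the two limits leave unreadable from compound 1 to compound 2, and a step that the two limits leave unreadable from compound 1 to compound 3. Both run from one limit to another, so the size of neither can be read, and neither tells whether exchanging the group on the carbonyl carbon or trimming a methoxy on the core moves the reading at all.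

Compound 4 `COc1cc(-c2cc(/C=C/C(=O)c3ccc(F)c(F)c3)[nH]n2)cc(OC)c1OC` is the compound still to be measured. It differs from compound 2 in one place: 3,4-difluorophenyl in place of 3,4-dichlorophenyl on a carbonyl carbon. Within the data shown here, the only step that bears on this change, the one from compound 1 to compound 2 at the same carbonyl carbon, is itself unreadable. The step to compound 4 is therefore expected to stay near the limit, with an estimated size of a step that the limit leaves unreadable from compound 2 to compound 4. Compound 4 is expected to give about 150000 nM, within a range from 50000 nM to 500000 nM, and most probably to be reported again only as a limit.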

Compound 4, concentration lethal to 50% of the cells: > 100000 nM
Compound 4: no number, only a limit (the forecaster's own chance of this, stated with the estimate: 75%); the middle value is on the limit's open side.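

In this assay compound 4 gives only a limit, as do compound 1 and compound 2, so neither new step, from compound 1 or from compound 2 to compound 4, can be read: the limit of > 100000 nM in this assay, at which 4 of the 4 values shown sit. The compounds shown leave open whether any change on the carbonyl carbon or the core moves the reading at all.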